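A few compounds are considered here, and "the series" means these few. Any claim that something is new, unique, unknown or untested is made for them only; others in the source may bear on it.

Compound 2 `CC/C(=C(/c1ccc(/C=C/C(=O)O)cc1)c1cc2ccccc2[nH]1)c1cccc(C(F)(F)F)c1` gives 325 nM in a functional assay on MCF7 cells (Homo sapiens) for inhibition (a higher number here means a weaker inhibitor, a lower number a stronger inhibitor), the highest of the two numbers recorded; its nearest neighbour, compound 1 `CC/C(=C(/c1ccc(/C=C/C(=O)O)cc1)c1cc2ccccc2[nH]1)c1ccccc1C`, gives 33 nM in this assay. Within the data shown here, the only measured step, a 9.8-fold higher number from compound 1 to compound 2 (0.99 log units; beyond the scatter), exchanged the group on that same chain carbon. Compound 3 `CC/C(=C(/c1ccc(/C=C/C(=O)O)cc1)c1cc2ccccc2[nH]1)c1cccc(Cl)c1Cl` differs from compound 2 by 2,3-dichlorophenyl in place of 3-(trifluoromethyl)phenyl on a double-bonded chain carbon bound to a double-bonded chain carbon and a saturated chain carbon. Since the 2,3-dichlorophenyl matches neither measured group, the lone step offers only a loose guide, and a modest move back toward the number of compound 1 is expected, a 3.0-fold lower number from compound 2 to compound 3 (0.47 log units; beyond the scatter). Compound 3 is therefore estimated at 110 nM, ranging from 30 nM to 400 nM.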

Compound 3, half-maximal inhibitory concentration: 898 nM
Estimate against measurement, compound 3: 8.2-fold (0.91 log units) below; the measured number lies above the stated range.
By their numbers in this assay, from the lowest: compound 1; then compound 2; then compound 3.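

With the 2,3-dichlorophenyl, this assay records a 2.8-fold higher number from compound 2 to compound 3 (0.44 log units; beyond the scatter) and a 27-fold higher number from compound 1 to compound 3 (1.43 log units; beyond the scatter) so this group ranks last of the three on this chain carbon. Both groups that replace the 2-methylphenyl thus give weaker inhibitors, and the two chlorines do not recover the number of compound 1. Nothing available explains this order. From the compounds shown here alone, whether the number of groups on this phenyl or their placing drives the loss stays open, as does how a single chlorine, a methoxy group or an amine there would compare.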